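The compounds below may be only part of what the source reports. "The series", "measured", "known", "first", "only" and "open" are said of these compounds alone.

Compound 2 `Cc1cccc(NC(=O)CSc2nnc(-c3ccoc3C)n2Cc2ccco2)c1C` carries a 2,3-dimethylphenyl group on its amide nitrogen. In a functional assay on CHO cells for antagonist activity at Orexin/Hypocretin receptor type 1 (Homo sapiens), read by FLIPR and calcium flux (on this read-out higher numbers stand for weaker inhibition and lower numbers for stronger inhibition), compound 2 gives only a limit, > 15800 nM. Its neighbour compound 1 `Cc1ccc(C)c(NC(=O)CSc2nnc(-c3ccoc3C)n2Cc2ccco2)c1` likewise gives only a limit, > 15800 nM. The step that the two limits leave unreadable from compound 1 to compound 2 therefore cannot be read, since both values sit at the limit of > 15800 nM in this assay, at which 2 of the 2 values shown sit. Compound 3 `COc1ccc(C)cc1NC(=O)CSc1nnc(-c2ccoc2C)n1Cc1ccco1` differs from compound 2 by 2-methoxy-5-methylphenyl in place of 2,3-dimethylphenyl on an amide-type nitrogen. Among the measured compounds shown here, with both measured compounds at the same limit, no measured step points in either direction, so compound 3 is expected to remain near that limit as well, with a step that the limit leaves unreadable from compound 2 to compound 3 meant by the estimate. Compound 3 is thus estimated at 20000 nM, within 8000 nM to 60000 nM.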

Compound 3, inhibition constant: 2510 nM
Estimate against measurement, compound 3: 8.0-fold (0.90 log units) above, outside the stated range (below it).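

On this aryl group on the amide nitrogen, a change of substituent can move the result in this assay: 2-methoxy-5-methylphenyl in place of 2,3-dimethylphenyl gives an at least 6.2-fold lower number from compound 2 to compound 3 (0.79 log units; beyond the scatter), meaning stronger inhibition. Methoxy in place of methyl on an aromatic carbon, a smaller change, gives an at least 6.2-fold lower number from compound 1 to compound 3 (0.79 log units; beyond the scatter). Compound 3 is therefore the only one of the three with a readable value, while the other two stop at a limit: the limit of > 15800 nM in this assay, at which 2 of the 3 values shown sit.

From the compounds shown here alone, the true size of both steps remains open, since each rests on a limit. Also open, going by these compounds, is whether an ethoxy group, a hydroxy group or a chlorine atom in place of the methoxy would give a similar result.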